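The compounds below may be only part of what the source reports. "The series", "measured", "known", "first", "only" and "open" are said of these compounds alone.

Compound 1 `NNC(=O)c1cc(-c2ccccc2)nn1Cc1ccccc1` is the parent of this small set; in a physicochemical assay for lipophilicity (a lower number here means a more polar compound, a higher number a more lipophilic compound), compound 1 gives 2.73. Compound 2 `CC(C)(C)c1ccc(Cn2nc(-c3ccccc3)cc2C(=O)NN)cc1` differs from it by tert-butyl in place of hydrogen on an aromatic carbon and in this assay compound 2 gives 4.49, a step of a number 1.76 log units higher from compound 1 to compound 2 (beyond the scatter). Compound 3 `COc1ccc(-c2cc(C(=O)NN)n(Cc3ccccc3)n2)cc1` carries a different core, the difference being (methoxy in place of hydrogen on an aromatic carbon); in this assay compound 3 gives 2.87, a step of a number 0.14 log units higher from compound 1 to compound 3 (within the scatter).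

Compound 4 `COc1ccc(-c2cc(C(=O)NN)n(Cc3ccc(C(C)(C)C)cc3)n2)cc1` is not yet measured. It stands to compound 3 as compound 2 stands to compound 1: the change is tert-butyl in place of hydrogen on an aromatic carbon, the same change in the same place. Among the measured compounds shown here, for compound 4 the expected step is a number 1.76 log units higher from compound 3 to compound 4 (beyond the scatter), set beside the measured step from compound 1 to compound 2, because that step a number 1.76 log units higher from compound 1 to compound 2 (beyond the scatter) is the only guide here. The estimate for compound 4 is 4.63, expected between 4.2 and 5.05.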

Compound 4, partition coefficient: 4.6
Estimate against measurement, compound 4: 0.03 log units above, and the stated range covers the measured number.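

In this assay the tert-butyl change on the core of compound 3 gives a number 1.73 log units higher from compound 3 to compound 4 (beyond the scatter) and so stands close to a number 1.76 log units higher from compound 1 to compound 2 (beyond the scatter) on the core of compound 1, while methoxy in place of hydrogen gives a number 0.11 log units higher from compound 2 to compound 4 (within the scatter) with the tert-butyl present. The change therefore carried over between this one pair of cores, but a single comparison gives no general rule for other cores or other assays. Nothing measured here says what lies behind this agreement.

The compounds shown leave open whether an amine, a carboxylic acid or a longer chain in the place of the tert-butyl would give a step of similar size. They also leave open whether any such step would carry from the core of compound 1 to the core of compound 3.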